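The source may report more compounds than this note shows. Statements on the series, on what has been measured and on what is new or still open speak of the compounds shown alone.

Of the compounds shown here, two have numbers so far. Compound 1 `Oc1ccccc1-c1c[nH]nn1` gives 96% in an assay on cells for inhibition of Indoleamine 2,3-dioxygenase 1 (Homo sapiens), with a stated time of 7 h, tested at 200 uM; a higher number here means more inhibition at the concentration tested (going by the name of the read-out), a lower number less inhibition. Compound 2 `Clc1cccc(-c2c[nH]nn2)c1/C=C/c1ccccc1` gives 32% in this assay; that is the lower of the two numbers, and the number for compound 1 stands higher by an amount beyond the usual scatter. Compound 1 and compound 2 differ in more than one place, so nothing is drawn from the gap between them beyond what the two values show.

The next compound, compound 3 `Clc1cccc(-c2c[nH]nn2)c1/C=C/C1CCCCC1`, has not yet been measured in this assay. It differs from compound 2 in one place: cyclohexyl in place of phenyl on a double-bonded chain carbon bound to a double-bonded chain carbon. Among the measured compounds shown here, no measured pair carries this change, so there is no step to lean on. The working expectation is a step from compound 2 to compound 3 of about a number 2 percentage points lower from compound 2 to compound 3 (within the scatter), that is, nothing clearly beyond the scatter in either direction, since compound 2 itself sits at 32% and the change keeps the same count of heavy atoms with no donors or acceptors. On that basis compound 3 is estimated at 30% in this assay, with a range from 10% to 55%.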

Compound 3, a percentage reported as inhibition, at one concentration (the size of the read-out at that concentration, not a potency): 56%
The estimate for compound 3 lay 26 percentage points below the measured number; the measured number lies above the stated range.
By their numbers in this assay, from the lowest: compound 2; then compound 3; then compound 1.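

In this assay, cyclohexyl in place of phenyl on a double-bonded chain carbon bound to a double-bonded chain carbon gives a number 24 percentage points higher from compound 2 to compound 3 (beyond the scatter), so this position responds to the identity of the ring even though the counts of heavy atoms, donors and acceptors stay the same. Among the compounds shown here, this is the first single-place step, and it shows that an aromatic ring is not needed at this position to keep inhibition at the tested concentration, with the non-aromatic ring reading higher of the pair. Nothing available explains why the non-aromatic ring reads higher.

One step at one position cannot show whether the rise belongs to cyclohexyl alone or extends to other groups at the same place, such as cyclopentyl, a straight hexyl chain, or a cyclohexyl ring carrying an amine or a carboxylic acid. Compound 1 differs from compound 3 in more than one place, so the route from one to the other stays unresolved, and a single-concentration read-out leaves potency itself open.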